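The source may report more compounds than this note shows. Statements on the series, on what has been measured and on what is new or still open speak of the compounds shown alone.

Measured compounds:
compound 1 `Nc1nc(N)c2c(CCc3ccc4ccccc4c3)cccc2n1`: 7.7
compound 2 `Nc1nc(S)c2ccccc2n1`: 4.37
compound 3 `Nc1ncnc2ccc(Sc3ccc4ccccc4c3)cc12`: 4.68

Of the compounds shown here, three have been tested in an assay for inhibition of Dihydrofolate reductase (Homo sapiens); a lower number here means a less potent compound, a higher number a more potent compound, by a factor of ten per unit of this negative logarithm. Compound 3 holds the second highest of the three numbers: its nearest neighbour is compound 2, which lies lower by a gap beyond the usual scatter, while compound 1 lies far higher. The new compound is compound 4 `Nc1nc(O)nc2ccc(Sc3ccc4ccccc4c3)cc12`, made from compound 3 by one change: hydroxy in place of hydrogen on an aromatic carbon. Within the data shown here, no measured pair shows a step of this kind, so the expectation rests only on the three numbers above. The hydroxy group enters the shared core with everything else kept as in compound 3, and the step is expected to be small, a number 0.08 log units lower from compound 3 to compound 4 (within the scatter), if anything slightly downward and not clearly beyond the scatter. Compound 4 is therefore estimated at 4.6, with a range from 3.9 to 5.4.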

Compound 4, logarithm of the reciprocal of the active concentration, log(1/C): 5.77
The estimate for compound 4 lay 1.17 log units below the measured number; the whole stated range lies below it.
By their numbers in this assay, from the lowest: compound 2; then compound 3; then compound 4; then compound 1.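

Hydroxy in place of hydrogen on this aromatic carbon, between two ring nitrogen atoms, gives a number 1.09 log units higher from compound 3 to compound 4 (beyond the scatter) in this assay. Among these compounds, this position is therefore sensitive to change: one added oxygen moves the number clearly, which the earlier compounds, with no pair differing in one place, could not show. Nothing available explains the gain.

On these data alone, it remains open whether a methyl or methoxy group at this position would give a similar step. As far as these compounds go, it is also open whether the hydroxy step would hold with a different side chain on the shared core.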